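This account rests on a few compounds, and the source may have more. Where it says the series, first, only, none or still open, it means among the compounds named here.

Measured compounds in an assay on isolated protein for inhibition of Amine oxidase [flavin-containing] A (Homo sapiens), read by fluorescence and Amplex Red, with a stated time of 30 min, tested at 0.01 uM; a lower number here means a weaker effect, a higher number a stronger effect of the compound at the concentration tested:
compound 1, `CC(C)CNc1nnc(SCC(=O)N(Cc2cccc([N+](=O)[O-])c2)c2ccc(F)cc2)s1`, giving 25.5%
compound 2, `COCCNc1nnc(SCC(=O)N(Cc2cccc([N+](=O)[O-])c2)c2ccc(F)cc2)s1`, giving 34.8%

Compound 2 holds the larger of the two numbers, but the step of a number 9.3 percentage points higher from compound 1 to compound 2 (within the scatter) lies within the scatter, so the two compounds are not separated by this assay and share the same level of inhibition for practical purposes.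

Compound 3, `C=CCNc1nnc(SCC(=O)N(Cc2cccc([N+](=O)[O-])c2)c2ccc(F)cc2)s1`, differs from compound 2 in one place: vinyl in place of methoxymethyl on a saturated chain carbon bound to a nitrogen on an aromatic ring. Within the data shown here, the only measured step, a number 9.3 percentage points higher from compound 1 to compound 2 (within the scatter), concerns the same place and likewise exchanges the group on the saturated chain carbon bound to the nitrogen on the aromatic ring; that exchange moved the inhibition by no more than the scatter. Among the measured compounds shown here, no measured pair shows the entry of vinyl, so nothing here indicates that removing the hydrogen-bond acceptor of methoxymethyl in favour of vinyl should change the read-out beyond the scatter, in either direction.

Compound 3 is therefore expected to give about 29% in this assay, in a range of 14% to 44%. The expected step of a number 5.8 percentage points lower from compound 2 to compound 3 (within the scatter) is estimated to stay within the scatter, close to the level set by compound 1 and compound 2.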

Compound 3, a percentage reported as inhibition, at one concentration (the size of the read-out at that concentration, not a potency): 32.7%
For compound 3 the middle estimate is 3.7 percentage points below the measured one; the range from low to high includes it.
By their numbers in this assay, from the lowest: compounds 1, 3 and 2 (each within the scatter of the next).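

In this assay, the exchange at this position on a saturated chain carbon bound to a nitrogen on an aromatic ring gives a number 2.1 percentage points lower from compound 2 to compound 3 (within the scatter) for vinyl in place of methoxymethyl, and a number 7.2 percentage points higher from compound 1 to compound 3 (within the scatter) for vinyl in place of isopropyl. Among these compounds, the hydrogen-bond acceptor of methoxymethyl can therefore be given up, and a double bond outside aromatic rings brought in, without separating the compounds, so isopropyl, methoxymethyl and vinyl now stand at one level across compound 1, compound 2 and compound 3, with no compound among them going against this. No supporting evidence is available on why these three groups sit at the same level.

Still open, from the compounds shown here alone, is whether any group at this position leaves that level, for instance a terminal carboxylic acid, a dimethylamino group or a longer chain such as n-hexyl, since the three groups compared here are all small and uncharged. The read-out also comes from a single concentration and is not a potency, so whether the three compounds would separate at other concentrations remains unanswered.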